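Truncating the urea side chain of compound 2 toward compound 3

The compounds below may be only part of what the source reports. "The series", "measured", "known", "first", "only" and "open" are said of these compounds alone.

Measured so far:
compound 1 `CC[C@H](C)[C@H](NC(=O)N1CCC2(CC1)CN(C)C2c1ccc(Cl)cc1)C(=O)OC` gives 410 nM in an assay on HEK293 cells for inhibition of Voltage-dependent T-type calcium channel subunit alpha-1H (Homo sapiens), read by patch clamp, using a membrane potential dye; a lower number here means a stronger inhibitor, a higher number a weaker inhibitor
compound 2 `CC[C@H](C)[C@H](NC(=O)N1CCC2(CC1)C(=O)N(c1cccc(F)c1)C2c1ccc(Cl)cc1)C(=O)OC(C)C` gives 45 nM in this assay

Of the two numbers in hand, compound 2 holds the lower one; compound 1 stands a good deal higher, and that gap is beyond the scatter. The two compounds differ in more than one place, so no single-change step can be read from them.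

Compound 3 `COC(=O)[C@H](CO)NC(=O)N1CCC2(CC1)C(=O)N(c1cccc(F)c1)C2c1ccc(Cl)cc1` keeps the whole spiro core and both aryl groups of compound 2 and changes only the urea side chain: a group of 7 heavy atoms (4 carbon, 3 oxygen; no ring) in place of a group of 11 heavy atoms (9 carbon, 2 oxygen; no ring), on an amide-type nitrogen. The entering group, 2-hydroxy-1-(methoxycarbonyl)ethyl, is smaller and brings a hydrogen-bond donor where none was.

Going by the values given here, no measured pair isolates this change, so any expectation is loose. Among the compounds with values here, the only related point is compound 1, which also carries a methyl ester and sits at 410 nM, but it differs from compound 2 elsewhere as well. A step upward is expected, of the size a 4.4-fold higher number from compound 2 to compound 3 (0.65 log units; beyond the scatter), beyond the scatter but short of the gap to compound 1. Compound 3 is estimated at 200 nM, with a range of 60 nM to 700 nM.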

Compound 3, half-maximal inhibitory concentration: 3330 nM
For compound 3 the middle estimate is 17-fold (1.22 log units) below the measured one, and the stated range ends below it.
By their numbers in this assay, from the lowest: compound 2; then compound 1; then compound 3.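

In this assay, the urea side chain on the amide-type nitrogen emerges as a position with a strong hold on the number: with the shared core and both aryl groups held constant, putting 2-hydroxy-1-(methoxycarbonyl)ethyl in place of the group of 11 heavy atoms gives a 74-fold higher number from compound 2 to compound 3 (1.87 log units; beyond the scatter) with no other part of the structure altered. This single-place step shows that the side chain alone can carry a large weakening, which could not be read from compound 1 and compound 2, as they differ in more than one place. No measurement in hand bears on why this step is so large.

This one change swaps the group of 11 heavy atoms for a smaller one and also brings in a hydrogen-bond donor, and the compounds shown do not separate these two differences. On these data alone, whether a carboxylic acid or an amine on this side chain, or a longer chain carrying the hydroxyl, would stay closer to compound 2 remains open.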